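The compounds below may be only part of what the source reports. "The series", "measured", "known", "first", "only" and "open" are said of these compounds alone.

Of the compounds shown here, three with a shared core have been tested in a functional assay on DU-145 cells (Homo sapiens) for cytotoxicity, read by MTT assay, with a stated time of 72 h; on this read-out lower numbers stand for an effect already at smaller amounts and higher numbers for an effect only at larger amounts of compound. Compound 1, `CCc1cccc2c(OC)c(-c3occ(C)c3C(=O)On3nnc4ccccc43)ccc12`, gives only a limit of the assay in this assay, > 10 ug/mL. Compound 2, `CCc1cccc2c(OC)c(-c3occ(C)c3CO)ccc12`, gives 7.2 ug/mL in this assay. Compound 3, `CCOc1c(-c2occ(C)c2CO)ccc2c(CC)cccc12`, likewise gives only a limit of the assay in this assay, > 10 ug/mL. Among the measured compounds shown here, the one measured step, an at least 1.3-fold higher number from compound 2 to compound 3 (0.14 log units; that floor lies within the scatter), therefore ends on a limit rather than a number, and compound 3 sits at the limit of > 10 ug/mL in this assay, at which 2 of the 3 values shown sit.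

Compound 4, `CCOc1c(-c2occ(C)c2COC(C)=O)ccc2c(CC)cccc12`, differs from compound 3 by acetyl in place of hydrogen on an oxygen on a saturated carbon: the hydroxymethyl becomes an acetoxymethyl. For the measured compounds named here, no measured step covers this exchange; the step from compound 2 to compound 3 touched a different place on the structure. With compound 3 already at a limit, the step expected in this assay is a step that the limit leaves unreadable from compound 3 to compound 4, nothing beyond the scatter. Compound 4 is therefore estimated at 15 ug/mL, with a range from 5 ug/mL to 40 ug/mL, and most likely the assay will again report only a limit.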

Compound 4, concentration for half-maximal effect: > 10 ug/mL
Compound 4: only a limit was reported; the forecaster's own chance of this, stated with the estimate: 70%; the middle value does not contradict the limit.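

Compound 3 and compound 4 both give only a limit in this assay rather than a number, so no step can be read for hydroxymethyl to acetoxymethyl: the limit of > 10 ug/mL in this assay, at which 3 of the 4 values shown sit. Still open, as far as these compounds go, is whether this exchange changes the effect at all, and how far apart compound 3 and compound 4 lie.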